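The source may hold more compounds than are shown below. What is called first, only, known or untested is meant among the compounds shown, and "the series" means these compounds.

Of the compounds shown here, three that share one core have been measured in an ADME assay on microsomes from liver (Rattus norvegicus) for metabolic stability; on this read-out higher numbers stand for a longer-lived compound and lower numbers for a shorter-lived compound. Compound 1 `COc1cc(OCc2cccc(-c3ccc(C#N)cc3)c2)c2cc(-c3cn4nc(OC)sc4n3)oc2c1` gives 1.67 h. Compound 2 `COc1cc(OCc2cccc(-c3ccc(C#N)cn3)c2)c2cc(-c3cn4nc(OC)sc4n3)oc2c1` gives 0.833 h, and compound 3 `COc1cc(OCc2cccc(-c3ccc(OC)nc3)c2)c2cc(-c3cn4nc(OC)sc4n3)oc2c1` gives 0.633 h. Compound 3 stands a 2.6-fold lower number from compound 1 to compound 3 (0.42 log units; beyond the scatter) and a 1.3-fold lower number from compound 2 to compound 3 (0.12 log units; within the scatter), so it sits apart from compound 1 but close to compound 2. Compound 4 `COc1cc(OCc2cccc(-c3cnc(OC)nc3)c2)c2cc(-c3cn4nc(OC)sc4n3)oc2c1` differs from compound 3 in one group only: 2-methoxypyrimidin-5-yl in place of 6-methoxypyridin-3-yl on an aromatic carbon. The steps that exchanged this same group were a 2.0-fold lower number from compound 1 to compound 2 (0.30 log units; within the scatter), a 2.6-fold lower number from compound 1 to compound 3 (0.42 log units; beyond the scatter) and a 1.3-fold lower number from compound 2 to compound 3 (0.12 log units; within the scatter), none of them large. Swapping one such ring for a related one has so far moved this assay little, so for compound 4 a step of a 1.2-fold lower number from compound 3 to compound 4 (0.06 log units; within the scatter) is expected. Compound 4 is estimated at 0.55 h, within 0.3 h to 1 h.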

Compound 4, half-life: 1.03 h
For compound 4 the middle estimate is 1.9-fold (0.27 log units) below the measured one; measured number above the stated range.
By their numbers in this assay, from the lowest: compounds 3, 2, 4 and 1 (each within the scatter of the next, the first and the last beyond it).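

In this assay, 2-methoxypyrimidin-5-yl in place of 6-methoxypyridin-3-yl gives a 1.6-fold higher number from compound 3 to compound 4 (0.21 log units; within the scatter), while the exchanges from the two nitrile-bearing rings give a 1.2-fold higher number from compound 2 to compound 4 (0.09 log units; within the scatter) and a 1.6-fold lower number from compound 1 to compound 4 (0.21 log units; within the scatter). Compound 4 therefore cannot be told apart from any of the three earlier compounds, even though compound 1 and compound 3 lie beyond the scatter of each other. No available information explains these results. Still open, as far as these compounds go, is whether a non-aromatic group at this place, such as a morpholine ring or a carboxylic acid, would move this assay beyond the scatter.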